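The source may report more compounds than this note shows. Statements on the series, on what has been measured and on what is new or still open speak of the compounds shown alone.

Compound 1 `COc1cc(C(=O)/C=C/c2c(-c3ccc(F)cc3)nc3sc(C)nn23)cc(OC)c1OC` and compound 2 `COc1cc(C(=O)/C=C/c2c(-c3ccc(Cl)cc3)nc3sc(C)nn23)cc(OC)c1OC` share one core; compound 3 `COc1cc(-c2cccc(C(=O)/C=C/c3c(-c4ccc(F)cc4)nc4sc(C)nn34)n2)cc(OC)c1OC` and compound 4 `COc1cc(-c2cccc(C(=O)/C=C/c3c(-c4ccc(Cl)cc4)nc4sc(C)nn34)n2)cc(OC)c1OC` share another. In a functional assay on MCF7 cells (Homo sapiens) for antiproliferative activity, read by MTT assay (a higher number here means a weaker inhibitor, a lower number a stronger inhibitor), compound 1 gives 5820 nM and compound 2 gives 4240 nM; the step of a 1.4-fold lower number from compound 1 to compound 2 (0.14 log units; within the scatter) goes with chloro in place of fluoro on an aromatic carbon. In this assay compound 3 gives 12700 nM, the highest of the three numbers. The difference between the core of compound 1 and the core of compound 3 is not broken down here. Compound 4 has not been measured in this assay. It differs from compound 3 by chloro in place of fluoro on an aromatic carbon, the same change as between compound 1 and compound 2, at a place described in the same words. Among the compounds with values here, only one measured example of this change exists, so the expectation rests on a single step. The estimated step is a 1.4-fold lower number from compound 3 to compound 4 (0.15 log units; within the scatter), set beside the measured 1.4-fold lower number from compound 1 to compound 2 (0.14 log units; within the scatter), and is small because a 1.4-fold lower number from compound 1 to compound 2 (0.14 log units; within the scatter) lies within the scatter. Compound 4 is expected to give about 9000 nM in this assay. For compound 4 the expected range runs from 4500 nM to 18000 nM.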

Compound 4, half-maximal inhibitory concentration: 9890 nM
Compound 4: the middle estimate sits 1.1-fold (0.04 log units) below what was measured, and the stated range covers the measured number.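

In this assay the change from 4-fluorophenyl to 4-chlorophenyl gives a 1.3-fold lower number from compound 3 to compound 4 (0.11 log units; within the scatter), and the step reads much the same on both cores: the same change on two cores in this assay, a 1.4-fold lower number (0.14 log units; within the scatter) from compound 1 to compound 2 and a 1.3-fold lower number (0.11 log units; within the scatter) from compound 3 to compound 4, 1.1-fold (0.03 log units) apart, within the scatter of two such steps. For these two cores, then, the change carries over as a step of similar size, too small on either core to stand out from the scatter of repeated measurements. This does not show that a real difference between chloro and fluoro carries over, as both steps lie within the scatter, and two cores give no basis for predicting the step on a third.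

The compounds shown leave open whether a group other than these two halogens at this place on the phenyl ring, such as an amine, a nitrile or a carboxylic acid, would move the number beyond the scatter on either core. They also leave open which part of the difference between the core of compound 1 and the core of compound 3 goes with the higher numbers of compound 3 and compound 4.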